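The source may report more compounds than this note shows. Statements on the series, on what has been measured and on what is new or still open speak of the compounds shown alone.

Measured compounds:
compound 1 `C#CCSc1nc(Nc2ccc(OC)cc2)c(C#N)c(-c2ccccc2)n1`: 35600 nM in a functional assay on MCF7 cells (Homo sapiens) for inhibition, read by MTT assay, with a stated time of 72 h; on this read-out higher numbers stand for weaker inhibition and lower numbers for stronger inhibition
compound 2 `C#CCSc1nc(Nc2ccccc2Cl)c(C#N)c(-c2ccccc2)n1`: 24200 nM
compound 3 `N#Cc1c(Nc2ccccc2Cl)nc(SCc2cn(Cc3ccccc3Cl)nn2)nc1-c1ccccc1`: 1950 nM

Compound 3 gives the lowest number of the three; the values of compound 1 and compound 2 lie above it by more than the scatter. Compound 4 `COc1ccccc1Nc1nc(SCc2cn(Cc3ccccc3Cl)nn2)nc(-c2ccccc2)c1C#N` differs from compound 3 by methoxy in place of chloro on an aromatic carbon. Within the data shown here, the only measured step that touches this ring is a 1.5-fold lower number from compound 1 to compound 2 (0.17 log units; within the scatter), which exchanged 4-methoxyphenyl for 2-chlorophenyl and stayed within the scatter; no measured step exchanges chloro for methoxy at the same position. With nothing pointing either way, compound 4 is expected to sit close to compound 3, with a 1.3-fold higher number from compound 3 to compound 4 (0.11 log units; within the scatter). Compound 4 is therefore estimated at 2500 nM, in a range from 800 nM to 8000 nM.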

Compound 4, half-maximal inhibitory concentration: 6170 nM
Estimate against measurement, compound 4: 2.5-fold (0.39 log units) below; low and high end bracket the measured number.
By their numbers in this assay, from the lowest: compound 3; then compound 4; then compounds 2 and 1 (each within the scatter of the next).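

In this assay, methoxy in place of chloro on an aromatic carbon ortho to a large group gives a 3.2-fold higher number from compound 3 to compound 4 (0.50 log units; beyond the scatter), a modest change but beyond the scatter. Among these compounds, the earlier step on this ring, a 1.5-fold lower number from compound 1 to compound 2 (0.17 log units; within the scatter), changed both the group and its place and stayed within the scatter, so this is the first exchange on this ring that the read-out separates. No measurement shown here bears on what lies behind the difference. As far as these compounds go, whether an amine or a carboxylic acid at this place would give a lower or a higher number remains open.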